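Growing a Methyl into a Benzyl on the Saturated Ring

A few compounds are considered here, and "the series" means these few. Any claim that something is new, unique, unknown or untested is made for them only; others in the source may bear on it.

Compound 1 `O=C(NC1CCCCC1)Oc1cccc(C2=NCCO2)c1`: 1.2 nM
Compound 2 `C[C@H]1COC(c2cccc(OC(=O)NC3CCCCC3)c2)=N1`: 51 nM
Compound 3 `C[C@@H]1COC(c2cccc(OC(=O)NC3CCCCC3)c2)=N1`: 16 nM

In an assay (strain Wistar) for inhibition of Fatty-acid amide hydrolase 1 (Rattus norvegicus), read by scintillation counting (a higher number here means a weaker inhibitor, a lower number a stronger inhibitor), compound 2 gives the highest number of the three. Compound 3, its mirror image, is closest, as a 3.2-fold lower number from compound 2 to compound 3 (0.50 log units; beyond the scatter) shows, and the difference rests on (the fact that compounds 2 and 3 differ only in the configuration as drawn). Compound 1 lies furthest away, as a 43-fold higher number from compound 1 to compound 2 (1.63 log units; beyond the scatter) shows. Compound 4 `O=C(NC1CCCCC1)Oc1cccc(C2=N[C@@H](Cc3ccccc3)CO2)c1` is compound 2 with phenyl in place of hydrogen on a saturated chain carbon bound to a saturated ring carbon. Going by the values given here, the steps that bear on this are the two methyl additions, a 43-fold higher number from compound 1 to compound 2 (1.63 log units; beyond the scatter) and a 13-fold higher number from compound 1 to compound 3 (1.12 log units; beyond the scatter), both large rises. Because those additions a 43-fold higher number from compound 1 to compound 2 (1.63 log units; beyond the scatter) and a 13-fold higher number from compound 1 to compound 3 (1.12 log units; beyond the scatter) weakened inhibition, a larger group at the same place is expected to weaken it further or leave it about the same, giving an expected step of a 2.9-fold higher number from compound 2 to compound 4 (0.47 log units; beyond the scatter). Compound 4 is therefore estimated at 150 nM, probably between 30 nM and 800 nM.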

Compound 4, half-maximal inhibitory concentration: 2100 nM
Beside the measured number, compound 4's estimate is 14-fold (1.15 log units) below it, and the stated range ends below it.
By their numbers in this assay, from the lowest: compound 1; then compound 3; then compound 2; then compound 4.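

The weakening does not level off once the methyl is in place: it continues as that methyl grows into a benzyl, with a 41-fold higher number from compound 2 to compound 4 (1.61 log units; beyond the scatter) in this assay. Measured from the unsubstituted core, the benzyl gives a 1800-fold higher number from compound 1 to compound 4 (3.24 log units; beyond the scatter), so this saturated ring carbon is a place where added size has so far only cost inhibition. Nothing shown here explains why the phenyl costs so much.

Going by these compounds, the mirror image of compound 4 remains open. So does whether an ethyl or a hydroxymethyl group at this place would land nearer compound 2 or compound 4.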